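Cytotoxicity limits across the cinnamoyl series; nitro for hydroxy

The source may hold more compounds than are shown below. What is called first, only, known or untested is meant among the compounds shown, and "the series" means these compounds.

Compound 1 `O=C(/C=C\c1ccccc1)N1N=C(c2ccncc2)OC1c1c[nH]c2ccccc12` carries the unsubstituted phenyl on the chain. In an ADME assay on HeLa cells (Homo sapiens) for cytotoxicity, read by MTT assay, with a stated time of 72 h (on this read-out higher numbers stand for weaker inhibition of growth and lower numbers for stronger inhibition of growth), compound 1 gives > 30 ug/mL, which is a limit of the assay and not a number. Compound 2 `O=C(/C=C\c1cccc(O)c1)N1N=C(c2ccncc2)OC1c1c[nH]c2ccccc12` is the hydroxy analogue, and in this assay compound 2 gives > 30 ug/mL, again a limit. Compound 3 `O=C(/C=C\c1ccccc1[N+](=O)[O-])N1N=C(c2ccncc2)OC1c1c[nH]c2ccccc12` is the ortho-nitro analogue, and in this assay compound 3 gives > 30 ug/mL, also a limit. Compound 2 therefore stands with the other two at the limit of > 30 ug/mL in this assay, at which 3 of the 3 values shown sit, and none of the three steps can be read: a step that the two limits leave unreadable from compound 1 to compound 2, a step that the two limits leave unreadable from compound 1 to compound 3 and a step that the two limits leave unreadable from compound 2 to compound 3.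

Compound 4 `O=C(/C=C\c1cccc([N+](=O)[O-])c1)N1N=C(c2ccncc2)OC1c1c[nH]c2ccccc12` is reached from compound 2 by nitro in place of hydroxy on an aromatic carbon. Within the data shown here, the steps that bear on it, nitro or hydroxy entering in place of hydrogen and nitro replacing hydroxy, all sit within the limit, so no readable size of step is expected in this assay; the step from compound 2 to compound 4 is estimated as a step that the limit leaves unreadable from compound 2 to compound 4. Compound 4 is expected at 40 ug/mL, within 25 ug/mL to 80 ug/mL, most likely reported as a limit.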

Compound 4, concentration for 50% growth inhibition: > 30 ug/mL
Compound 4 ended at the assay's limit (the forecaster's own chance of this, stated with the estimate: 85%); the middle value does not contradict the limit.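

No new step can be read for compound 4: together with compound 1, compound 2 and compound 3, it gives only a limit in this assay, and no step among the four has a size: the limit of > 30 ug/mL in this assay, at which 4 of the 4 values shown sit.

As far as these compounds go, whether hydroxy or nitro on the phenyl changes growth inhibition at all remains open.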